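Thioamide series on the shared core: nitrogen substituent

The source may hold more compounds than are shown below. What is called first, only, known or untested is meant among the compounds shown, and "the series" means these compounds.

In a functional assay on PC-3 cells (Homo sapiens) for cytotoxicity, read by sulforhodamine B assay, with a stated time of 72 h (on this read-out higher numbers stand for weaker inhibition and lower numbers for stronger inhibition), compound 1 `Nc1sc(-c2ccc(Cl)cc2)c(-c2ccc(Cl)cc2)c1C(=O)NC1CCCCC1` gives 7300 nM. Compound 2 `Nc1sc(-c2ccc(Cl)cc2)c(-c2ccc(Cl)cc2)c1C(=S)NC1CC1` gives 22100 nM in this assay, and compound 3 `Nc1sc(-c2ccc(Cl)cc2)c(-c2ccc(Cl)cc2)c1C(=S)NC1CCCCC1` gives 27700 nM. Compound 3 carries the highest number of the three: a 3.8-fold higher number from compound 1 to compound 3 (0.58 log units; beyond the scatter), whereas a 1.3-fold higher number from compound 2 to compound 3 (0.10 log units; within the scatter). Compound 4 `CC(C)(C)NC(=S)c1c(N)sc(-c2ccc(Cl)cc2)c1-c1ccc(Cl)cc1` differs from compound 3 by tert-butyl in place of cyclohexyl on an amide-type nitrogen. The measured step that bears on this change is the one on the same amide-type nitrogen, a 1.3-fold higher number from compound 2 to compound 3 (0.10 log units; within the scatter), which lies within the scatter; the steps of a 3.0-fold higher number from compound 1 to compound 2 (0.48 log units; beyond the scatter) and a 3.8-fold higher number from compound 1 to compound 3 (0.58 log units; beyond the scatter) also exchange the carbonyl for a thiocarbonyl and so do not isolate the nitrogen substituent. For compound 4 no step beyond the scatter is therefore expected in this assay: a 1.1-fold lower number from compound 3 to compound 4 (0.04 log units; within the scatter). The estimate for compound 4 is 25000 nM, with a range from 9000 nM to 65000 nM.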

Compound 4, half-maximal inhibitory concentration: 34000 nM
Compound 4: middle estimate off by 1.4-fold (0.13 log units), on the low side; the range from low to high includes it.
By their numbers in this assay, from the lowest: compound 1; then compounds 2, 3 and 4 (each within the scatter of the next).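

In this assay the tert-butyl group, which has no ring, stays within the scatter of both ring-bearing groups on the amide-type nitrogen (a 1.2-fold higher number from compound 3 to compound 4 (0.09 log units; within the scatter)) and (a 1.5-fold higher number from compound 2 to compound 4 (0.19 log units; within the scatter)). Across cyclopropyl, cyclohexyl and tert-butyl the thioamide compounds show no separation, while the step from the carbonyl compound stays beyond the scatter (a 4.7-fold higher number from compound 1 to compound 4 (0.67 log units; beyond the scatter)), although it also exchanges the nitrogen substituent. No available evidence accounts for these numbers.

From the compounds shown here alone, whether a benzyl group or a longer chain ending in an amine on this nitrogen would leave this band remains open, as does the value of the carbonyl counterpart of compound 4.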